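Swapping 5-methylpyridin-2-yl for 1,3-oxazol-2-yl: an estimate

The compounds below may be only part of what the source reports. "The series", "measured", "known", "first", "only" and "open" are said of these compounds alone.

Measured compounds:
compound 1, `O=C(O)CCn1c(=O)oc2cc(Cl)c(Cl)cc21`: 6.31 nM
compound 2, `Cc1ccc([C@@H](C)Oc2cc3oc(=O)n(CCC(=O)O)c3cc2Cl)nc1`: 3.16 nM

Two compounds have been run in an assay for inhibition of kynurenine 3-monooxygenase (Homo sapiens), read by mass spectrometry, with a stated time of 1 h; on this read-out lower numbers stand for stronger inhibition and higher numbers for weaker inhibition. Compound 1 gives 6.31 nM in this assay, and compound 2 gives 3.16 nM. Compound 2 has the lowest of the two numbers, but its nearest neighbour, compound 1, lies within the usual scatter, so the two cannot be told apart on these data.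

Compound 3, `C[C@@H](Oc1cc2oc(=O)n(CCC(=O)O)c2cc1Cl)c1ncco1`, is the next member. It differs from compound 2 by 1,3-oxazol-2-yl in place of 5-methylpyridin-2-yl on a saturated chain carbon bound to an oxygen on an aromatic ring and a saturated chain carbon. Going by the values given here, no pair of measured compounds shares a change of this kind, so there is no measured step to lean on; the only guide is that both measured compounds sit close together at the low end of the scale.

Compound 3 is expected to remain in the same region, with a step of a 2.5-fold higher number from compound 2 to compound 3 (0.40 log units; beyond the scatter) toward a somewhat higher number, and a wide range around it. The estimated value for compound 3 in this assay is 8 nM, between 2.5 nM and 25 nM.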

Compound 3, half-maximal inhibitory concentration: 3.16 nM
Estimate against measurement, compound 3: 2.5-fold (0.40 log units) above; the range from low to high includes it.
By their numbers in this assay, from the lowest: compounds 2, 3 and 1 (each within the scatter of the next).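

In this assay, 1,3-oxazol-2-yl in place of 5-methylpyridin-2-yl on a saturated chain carbon bound to an oxygen on an aromatic ring and a saturated chain carbon gives no change at the digits printed from compound 2 to compound 3 (within the scatter) and so the two groups cannot be told apart at this place, even though the entering five-membered aromatic ring has 5 heavy atoms and 2 hydrogen-bond acceptors, against 7 heavy atoms and 1 hydrogen-bond acceptor for the six-membered ring that leaves. The group of 8 heavy atoms that stands in place of one chlorine atom, on an aromatic carbon, gives a 2.0-fold lower number from compound 1 to compound 3 (0.30 log units; within the scatter) and thus adds this oxazole-bearing group to the shared core without a step beyond the scatter. Nothing at hand explains why these groups read alike.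

As far as these compounds go, both rings compared at this place are aromatic and carry a ring nitrogen, so it remains open whether a plain phenyl ring, a cyclohexyl ring or a simple methyl group on the same saturated chain carbon would read alike in this assay as well. From the compounds shown here alone, it also remains open whether the carboxylic acid, which all three compounds share, could give way to an amide or a tetrazole.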